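Swapping a Tolyl for a Bromophenyl on the Anilino Nitrogen

The compounds below may be only part of what the source reports. "The series", "measured", "known", "first", "only" and "open" are said of these compounds alone.

Of the compounds shown here, three sharing one core have been tested in an assay on isolated protein for inhibition of beta-glucuronidase (Bos taurus), read by spectrophotometry, with a stated time of 30 min; a higher number here means a weaker inhibitor, a lower number a stronger inhibitor. Compound 1 `COc1ccc(Nc2nnc(-c3ccccc3Cl)s2)cc1` gives 22600 nM in this assay. Compound 2 `Clc1ccc(Nc2nnc(-c3ccccc3Cl)s2)cc1Cl` gives 2160 nM in this assay. Compound 3 `Cc1ccc(Nc2nnc(-c3ccc(C)cc3C)s2)cc1` gives 34300 nM in this assay, the highest of the three numbers; the number for compound 1 sits close to it, within the usual scatter, whereas the number for compound 2 lies well apart, beyond the scatter. No two of these compounds differ in only one place, so the readings are compared here only as they stand.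

Compound 4 `Cc1ccc(-c2nnc(Nc3cccc(Br)c3)s2)c(C)c1` has not yet been measured. It is built from compound 3 by a single change: 3-bromophenyl in place of 4-methylphenyl on a nitrogen on an aromatic ring. Among the measured compounds, the only one carrying halogens on the ring attached to that nitrogen is compound 2, whose value of 2160 nM is the lowest seen. On that basis compound 4 is expected to give a lower number than compound 3, with a step of a 3.4-fold lower number from compound 3 to compound 4 (0.54 log units; beyond the scatter) estimated, somewhat beyond the scatter. The estimate for compound 4 in this assay is 10000 nM, with a range from 3000 nM to 35000 nM.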

Compound 4, half-maximal inhibitory concentration: 36100 nM
For compound 4 the middle estimate is 3.6-fold (0.56 log units) below the measured one; measured number above the stated range.
By their numbers in this assay, from the lowest: compound 2; then compounds 1, 3 and 4 (each within the scatter of the next).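

In this assay, putting 3-bromophenyl in place of 4-methylphenyl on a nitrogen on an aromatic ring gives a 1.1-fold higher number from compound 3 to compound 4 (0.02 log units; within the scatter), so this reading cannot tell the two groups apart. Everything else in the two molecules stays the same. Among these compounds, this pair is the first direct view of this position, and it shows that this particular exchange of a methyl-bearing ring for a bromine-bearing ring leaves the reading within the scatter. Nothing measured here offers an explanation for why the two compounds read alike.

On these data alone, whether a more different group on that nitrogen, such as a phenyl ring carrying an amine or a carboxylic acid, or a longer chain in place of the ring, would shift the number remains open. Compound 4 differs from compound 2 in more than one place, so the reading of compound 2 at 2160 nM cannot be traced to any single group, and what lies behind that number stays unsettled.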